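The source may hold more compounds than are shown below. What is called first, only, known or untested is meant among the compounds shown, and "the series" means these compounds.

Measured so far: compound 1 `COCC(=O)N(Cc1ccc(OC)c(O)c1)c1cc(OC)c(OC)c(OC)c1`, 230 nM; compound 2 `C=CC(=O)N(Cc1ccc(OC)c(O)c1)c1cc(OC)c(OC)c(OC)c1`, 98 nM.

In a functional assay on HCT-116 cells (Homo sapiens) for inhibition, read by MTT assay, with a stated time of 48 h (on this read-out higher numbers stand for weaker inhibition and lower numbers for stronger inhibition), compound 2 stands with the lowest of the two numbers. Among the compounds with values here, the only measured step, a 2.3-fold lower number from compound 1 to compound 2 (0.37 log units; beyond the scatter), also changed the group on the carbonyl carbon. Compound 3 `COc1ccc(CN(C(=O)CCCCCl)c2cc(OC)c(OC)c(OC)c2)cc1O` differs from compound 2 by 4-chlorobutyl in place of vinyl on a carbonyl carbon. That one step bears on this change, and it was modest, so a modest step is expected, with the number moving back toward that of compound 1. Compound 3 is therefore estimated at 250 nM (range 100 nM to 700 nM), a step of a 2.6-fold higher number from compound 2 to compound 3 (0.41 log units; beyond the scatter) in this assay.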

Compound 3, half-maximal inhibitory concentration: 220 nM
Compound 3: the middle estimate sits 1.1-fold (0.06 log units) above what was measured; measured number inside the range.
By their numbers in this assay, from the lowest: compound 2; then compounds 3 and 1 (each within the scatter of the next).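

In this assay, replacing vinyl on the carbonyl carbon with a longer saturated chain does not preserve the number of compound 2 (a 2.2-fold higher number from compound 2 to compound 3 (0.35 log units; beyond the scatter)). The 4-chlorobutyl and methoxymethyl groups cannot be separated (a 1.0-fold lower number from compound 1 to compound 3 (0.02 log units; within the scatter)), so among these three compounds only the vinyl group of compound 2 stands apart. No evidence bears on the reason for this.

On these data alone, compound 2 alone carries a double bond here, so whether an ethyl group on the same carbonyl carbon would keep its number stays open. Also open, as far as these compounds go, is whether a butyl chain without the chlorine, or one ending in an amine, would differ from compound 3.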